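Pyridine attachment point on the shared core

The source may hold more compounds than are shown below. What is called first, only, known or untested is meant among the compounds shown, and "the series" means these compounds.

Compound 1 `O=C(/C=C/c1cn(-c2ccccc2)nc1-c1cccnc1)c1ccsc1` and compound 2 `O=C(/C=C/c1cn(-c2ccccc2)nc1-c1cccnc1)c1ccccc1` share one core and differ only in the group on the carbonyl carbon. Within the data shown here, in a functional assay on Huh-7 cells (Homo sapiens) for inhibition, read by sulforhodamine B assay, with a stated time of 72 h (a higher number here means a weaker inhibitor, a lower number a stronger inhibitor), compound 1 gives 1700 nM, and the only other number, from compound 2, 2300 nM, lies within the scatter of it, as the step of a 1.4-fold higher number from compound 1 to compound 2 (0.13 log units; within the scatter) shows. Compound 3 `O=C(/C=C/c1cn(-c2ccccc2)nc1-c1ccncc1)c1ccsc1` keeps the thiophen-3-yl ketone of compound 1 and differs from it by pyridin-4-yl in place of pyridin-3-yl on an aromatic carbon, the same atoms joined differently. Among the measured compounds shown here, no measured step touches the pyridyl group: the one step recorded, a 1.4-fold higher number from compound 1 to compound 2 (0.13 log units; within the scatter), concerns the carbonyl substituent and does not bear on this change. With nothing to show that the shift from pyridin-3-yl to pyridin-4-yl matters, no step beyond the scatter is expected in this assay, in either direction, and the estimated step of no change at the digits printed from compound 1 to compound 3 (within the scatter) is set close to no change. For compound 3 the expected value in this assay is 1700 nM, with a range of 600 nM to 5000 nM.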

Compound 3, half-maximal inhibitory concentration: 2200 nM
For compound 3 the middle estimate is 1.3-fold (0.11 log units) below the measured one, within the range that was stated.
By their numbers in this assay, from the lowest: compounds 1, 3 and 2 (each within the scatter of the next).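

Among these compounds, changing pyridin-3-yl to pyridin-4-yl on an aromatic carbon, with the thiophen-3-yl ketone held fixed, gives the first reading at this position: a 1.3-fold higher number from compound 1 to compound 3 (0.11 log units; within the scatter) in this assay. Within this pair, the two pyridyl isomers cannot be told apart, so the attachment point of the pyridine is not shown to matter in this assay. No available evidence accounts for this result.

On these data alone, whether this position accepts anything other than a pyridine ring remains open, for example a plain phenyl group, or a pyridin-3-yl ring carrying an amine or a carboxylic acid. As far as these compounds go, it is also open whether pyridin-4-yl gives a similar reading when phenyl, rather than thiophen-3-yl, sits on the carbonyl carbon.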